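Swapping the aryl group on a fused thienopyrimidine antagonist

The compounds below may be only part of what the source reports. "The series", "measured", "known", "first", "only" and "open" are said of these compounds alone.

Of the compounds shown here, two of a shared core have been measured in a functional assay on CHO-K1 cells for antagonist activity at adenosine receptor A1 (Homo sapiens), read by a beta-galactosidase reporter and cAMP accumulation, with stated times of 15 min and 6 h; on this read-out lower numbers stand for stronger inhibition and higher numbers for weaker inhibition. Compound 1 `N#Cc1ccc(-c2nc(N)c3cc(Cc4ccccc4)sc3n2)o1` carries a 5-cyanofuran-2-yl group and a benzyl group on the core; in this assay compound 1 gives 3160 nM. Compound 2 `COc1ccccc1Cc1cc2c(N)nc(-c3nc(C)cs3)nc2s1` differs in more than one place, carrying a 4-methylthiazol-2-yl group and a 2-methoxybenzyl group; in this assay compound 2 gives 186 nM. Of the two numbers, that of compound 1 is the higher, and the gap to compound 2 lies beyond the usual scatter. For the measured compounds named here, no pair differing in a single place has yet been measured, so the weight of any one change is not known.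

Compound 3 `Nc1nc(-c2ccncc2)nc2sc(Cc3ccccc3)cc12` is not yet measured. It differs from compound 1 as follows: pyridin-4-yl in place of 5-cyanofuran-2-yl on an aromatic carbon. The change is on the aromatic carbon that sits between two ring nitrogen atoms of the core. Since compound 2, with a different aryl group in that place, gives 186 nM, a modest move toward lower numbers is expected, as a 4.0-fold lower number from compound 1 to compound 3 (0.60 log units; beyond the scatter). Compound 3 is estimated at 800 nM, within a range from 150 nM to 4000 nM.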

Compound 3, inhibition constant: 812 nM
The estimate for compound 3 lay 1.0-fold (0.01 log units) below the measured number; the measured number falls inside the stated range.
By their numbers in this assay, from the lowest: compound 2; then compound 3; then compound 1.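

Compound 1 and compound 3 form the first pair differing in a single place, and in this assay the exchange gives a 3.9-fold lower number from compound 1 to compound 3 (0.59 log units; beyond the scatter) while the benzyl group and the rest of the shared core stay the same. This shows that the aromatic carbon between two ring nitrogen atoms responds on its own to a change of aryl group, by a modest step that lies beyond the usual scatter. No measurement bears on why the number moves, and this single exchange changes the ring size, the hetero atom and the presence of the nitrile together.

Which of these changes carries the step stays open, and a furan-2-yl group without the nitrile or a plain phenyl group on the same carbon would begin to separate them. Compound 2 still differs from compound 3 in both the group on this carbon and the group on the benzyl position, so the separate weights of the 4-methylthiazol-2-yl and 2-methoxybenzyl groups cannot be read.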